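This account rests on a few compounds, and the source may have more. Where it says the series, first, only, none or still open, it means among the compounds named here.

Working notes on the series. Compound 1 `O=c1[nH]c2ccccc2cc1-c1nc2cc([N+](=O)[O-])ccc2[nH]1` and compound 2 `COc1ccc2[nH]c(=O)c(-c3nc4cc(Cl)ccc4[nH]3)cc2c1` share a common core and have each been tested in a functional assay on HepG2 cells (Homo sapiens) for cytotoxicity, read by MTT assay, with a stated time of 48 h; a higher number here means a weaker inhibitor, a lower number a stronger inhibitor. In this assay compound 1 gives > 100000 nM, which is a limit of the assay and not a number. In this assay compound 2 gives > 100000 nM, likewise a limit rather than a number. Compound 2 therefore stands at the ceiling of the range, as shown by the limit of > 100000 nM in this assay, at which 2 of the 2 values shown sit, and nothing more is known of its ranking against compound 1.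

Compound 3 `COc1ccc2[nH]c(=O)c(-c3nc4cc([N+](=O)[O-])ccc4[nH]3)cc2c1` has not yet been measured. The change from compound 2 is nitro in place of chloro on an aromatic carbon. Compound 1 carries the same nitro group and sits at the limit, so no step beyond the scatter is expected in this assay. The expected step of a number no higher from compound 2 to compound 3 (the limit leaves the size open) is essentially none. The estimate for compound 3 in this assay is 100000 nM, ranging from 50000 nM to 300000 nM, with a limit the most likely outcome.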

Compound 3, half-maximal inhibitory concentration: > 100000 nM
Compound 3 ended at the assay's limit; the forecaster's own chance of this, stated with the estimate: 85%; the middle value lies on the limit itself.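

No step among compound 1, compound 2 and compound 3 can be read in this assay, since each result is a limit of the assay and not a number: the limit of > 100000 nM in this assay, at which 3 of the 3 values shown sit.

The compounds shown leave open whether nitro in place of chloro or methoxy in place of hydrogen changes cytotoxicity at all.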